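Chloro added on the aryl ring of compound 3

A few compounds are considered here, and "the series" means these few. Any claim that something is new, unique, unknown or untested is made for them only; others in the source may bear on it.

In a functional assay on the whole organism with Mus musculus as the target (on this read-out higher numbers stand for an effect only at larger amounts of compound and lower numbers for an effect already at smaller amounts), compound 1 `OC1CCN(c2ccc(-c3ccccc3Cl)nn2)CC1` gives 38 mg/kg. Compound 2 `OC1CCN(c2ccc(-c3ccc(Cl)cc3Cl)nn2)CC1` gives 8.5 mg/kg in this assay; the change from compound 1 is chloro in place of hydrogen on an aromatic carbon, and the step is a 4.5-fold lower number from compound 1 to compound 2 (0.65 log units; beyond the scatter). Compound 3 `Cc1ccccc1-c1ccc(N2CCC(O)CC2)nn1` gives 40 mg/kg in this assay; it differs from compound 1 by methyl in place of chloro on an aromatic carbon, and the step of a 1.1-fold higher number from compound 1 to compound 3 (0.02 log units; within the scatter) is within scatter, so the two cores read alike.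

Compound 4 `Cc1cc(Cl)ccc1-c1ccc(N2CCC(O)CC2)nn1` is not yet measured in this assay. From compound 3 it differs by chloro in place of hydrogen on an aromatic carbon. Going by the values given here, this is the same kind of change as the one from compound 1 to compound 2, though here the entering chloro sits meta to a methyl group rather than meta to a chloro group. On the strength of compound 2 alone, the step is expected to be a 4.0-fold lower number from compound 3 to compound 4 (0.60 log units; beyond the scatter), set beside a 4.5-fold lower number from compound 1 to compound 2 (0.65 log units; beyond the scatter). Compound 4 is therefore estimated at 10 mg/kg, expected between 5 mg/kg and 22 mg/kg; compound 3 with 40 mg/kg is the only anchor for this expectation.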

Compound 4, dose for half-maximal effect: 10 mg/kg
Compound 4: the middle estimate sits on the measured number at the digits printed, within the range that was stated.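

In this assay chloro in place of hydrogen on an aromatic carbon carries over between the two cores, the new step being (a 4.0-fold lower number from compound 3 to compound 4 (0.60 log units; beyond the scatter)): the same change on two cores in this assay, a 4.5-fold lower number (0.65 log units; beyond the scatter) from compound 1 to compound 2 and a 4.0-fold lower number (0.60 log units; beyond the scatter) from compound 3 to compound 4, 1.1-fold (0.05 log units) apart, within the scatter of two such steps. Methyl in place of chloro on an aromatic carbon stays without a readable effect on either core, the new step being (a 1.2-fold higher number from compound 2 to compound 4 (0.07 log units; within the scatter)): the same change on two cores in this assay, a 1.1-fold higher number (0.02 log units; within the scatter) from compound 1 to compound 3 and a 1.2-fold higher number (0.07 log units; within the scatter) from compound 2 to compound 4, 1.1-fold (0.05 log units) apart, within the scatter of two such steps. Going by these compounds alone, these are only two pairs of closely related compounds, which show the two changes combining consistently within this set but give no reason for it and no guarantee for other cores.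

Still open, on these data alone, is whether a different group at that aromatic carbon, such as an amine or a carboxylic acid, gives a step of like size. Also open, as far as these compounds go, is whether the chloro step holds with a longer chain in place of the methyl group.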